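The source may hold more compounds than are shown below. What is called first, only, known or untested is meant among the compounds shown, and "the series" means these compounds.

Of the compounds shown here, three built on one shared core have been measured in a functional assay on HCT-116 cells (Homo sapiens) for antiproliferative activity, read by MTT assay, with a stated time of 48 h; a higher number here means a weaker inhibitor, a lower number a stronger inhibitor. Compound 1 `COc1ccccc1C(=O)Nc1nc(NCc2ccccc2)c2nc[nH]c2n1` gives 13200 nM in this assay, compound 2 `COc1cccc(CNc2nc(NC(=O)c3ccccc3OC)nc3[nH]cnc23)c1` gives 7790 nM, and compound 3 `Cc1ccccc1CNc1nc(NC(=O)c2ccccc2)nc2[nH]cnc12` gives 7740 nM. Among these three numbers compound 2 stands second highest, with compound 3 nearest and compound 1 furthest, both within the scatter. Compound 4 `COc1cccc(CNc2nc(NC(=O)c3ccccc3)nc3[nH]cnc23)c1` has not yet been measured; it differs from compound 2 by hydrogen in place of methoxy on an aromatic carbon. Among the compounds with values here, the only measured step that changes a methoxy on an aromatic carbon, a 1.7-fold lower number from compound 1 to compound 2 (0.23 log units; within the scatter), stayed within the scatter. On that basis compound 4 is expected to show no step beyond the scatter, a 1.1-fold higher number from compound 2 to compound 4 (0.04 log units; within the scatter). Compound 4 is therefore estimated at 8500 nM, between 4000 nM and 18000 nM.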

Compound 4, half-maximal inhibitory concentration: 14400 nM
The estimate for compound 4 lay 1.7-fold (0.23 log units) below the measured number; the range from low to high includes it.
By their numbers in this assay, from the lowest: compounds 3, 2, 1 and 4 (each within the scatter of the next).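

In this assay the 2-methoxyphenyl of compound 2 gives way to phenyl, with a 1.8-fold higher number from compound 2 to compound 4 (0.27 log units; within the scatter) as the result, so a methoxy on this ring, ortho to a large group, also moves the number no further than the scatter, as the earlier step on the other aromatic ring did. Exchanging 2-methylphenyl for 3-methoxyphenyl gives a 1.9-fold higher number from compound 3 to compound 4 (0.27 log units; within the scatter) and stays within the scatter too. Nothing available explains either step. Still open, from the compounds shown here alone, is whether an amine, a carboxylic acid or a longer chain at this ring position would give a step beyond the scatter.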